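The source may report more compounds than this note shows. Statements on the series, on what has been measured and on what is new or still open speak of the compounds shown alone.

Working notes on the series. Two compounds carry a measurement in a functional assay on HeLa cells (Homo sapiens) for cytotoxicity, read by MTT assay, with a stated time of 72 h, tested at 3 uM; on this read-out lower numbers stand for less inhibition of growth and higher numbers for more inhibition of growth at the one concentration tested. Compound 1 `Cc1cccc(/C(N)=N/NC(=S)N2CCN(c3ccccn3)CC2)n1` gives 72.7% and stands highest of the two numbers. Compound 2 `N/C(=N\NC(=S)N1CCCCCC1)c1ccccn1` differs from compound 1 in several places. In this assay, for the measured compounds named here, compound 2 gives 36.6%, a number well beyond the scatter below that of compound 1; no single-point step between the two is recorded, so the pair shows only that compound 1 inhibits growth more strongly at the one concentration tested.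

The next compound, compound 3 `Cc1ccnc(/C(N)=N/NC(=S)N2CCN(c3ccccn3)CC2)c1`, is not yet measured in this assay. Its relation to compound 1 is 4-methylpyridin-2-yl in place of 6-methylpyridin-2-yl on a carbon with a double bond to nitrogen. The core is kept, the groups attached to the piperazine are kept, and only the position of the methyl on the pyridinyl ring changes. Going by the values given here, with no measured step of this kind on hand, the expected change in this assay is small, perhaps a slight loss, and may fall within the scatter. For compound 3 the expected step is a number 7.7 percentage points lower from compound 1 to compound 3 (within the scatter). Compound 3 is thus estimated at 65%, with a range of 42% to 84%.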

Compound 3, percent growth inhibition at one concentration: 42.5%
For compound 3 the middle estimate is 22.5 percentage points above the measured one, and the stated range covers the measured number.
By their numbers in this assay, from the lowest: compounds 2 and 3 (each within the scatter of the next); then compound 1.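

In this assay, the position of the methyl on the pyridinyl ring is not a neutral feature: 4-methylpyridin-2-yl in place of 6-methylpyridin-2-yl on a carbon with a double bond to nitrogen gives a number 30.2 percentage points lower from compound 1 to compound 3 (beyond the scatter). For the compounds shown here, this is the first step that differs in one place, and since the two compounds have the same atoms, the placement of the methyl alone is enough to shift the read-out beyond the scatter, which the earlier pair, differing in several places, could not show. No measurement bearing on this result is available, so the step stands without an explanation.

The compounds shown leave open how a plain pyridin-2-yl without any methyl would compare at this place, and whether a methoxy group or a chlorine atom carried in place of the methyl would follow compound 1 or compound 3. They also leave open whether the step holds when the pyridinyl group on the piperazine is replaced, for instance by a phenyl ring.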